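This account rests on a few compounds, and the source may have more. Where it says the series, first, only, none or still open, it means among the compounds named here.

Measured so far: compound 1 `Fc1ccc(-n2cc(CSc3nc4cc(OC(F)F)ccc4[nH]3)nn2)cc1F` gives 65300 nM in a functional assay on PC-3 cells (Homo sapiens) for cytotoxicity, read by MTT assay, with a stated time of 72 h; on this read-out lower numbers stand for stronger inhibition and higher numbers for weaker inhibition; compound 2 `FC(F)Oc1ccc2[nH]c(SCc3cn(-c4cccc(Cl)c4Cl)nn3)nc2c1` gives 69800 nM in this assay.

Compound 2 stands alongside compound 1, the two separated by a 1.1-fold higher number from compound 1 to compound 2 (0.03 log units; within the scatter), so their numbers lie within the scatter of each other. Compound 3 `O=[N+]([O-])c1ccc(-n2cc(CSc3nc4cc(OC(F)F)ccc4[nH]3)nn2)cc1` differs from compound 2 in one place: 4-nitrophenyl in place of 2,3-dichlorophenyl on an aromatic nitrogen. Going by the values given here, the one measured step that bears on this change is a 1.1-fold higher number from compound 1 to compound 2 (0.03 log units; within the scatter), which was likewise a swap of the aryl group on that aromatic nitrogen and left the number essentially where it was. Among the compounds with values here, with only that step as a guide, compound 3 is expected to show no step beyond the scatter in this assay in either direction, an expected step of a 1.0-fold higher number from compound 2 to compound 3 (0.00 log units; within the scatter). Compound 3 is therefore estimated at 70000 nM, with a range from 35000 nM to 140000 nM.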

Compound 3, half-maximal inhibitory concentration: 59300 nM
Beside the measured number, compound 3's estimate is 1.2-fold (0.07 log units) above it; the range from low to high includes it.
By their numbers in this assay, from the lowest: compounds 3, 1 and 2 (each within the scatter of the next).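

In this assay the step of a 1.2-fold lower number from compound 2 to compound 3 (0.07 log units; within the scatter) and the step of a 1.1-fold lower number from compound 1 to compound 3 (0.04 log units; within the scatter) show that a 4-nitrophenyl group on this aromatic nitrogen reads the same, within the scatter, as the 2,3-dichlorophenyl and 3,4-difluorophenyl groups. The earlier pair compared only halogenated aryl groups, whereas this result extends the flat picture to an aryl group carrying no halogen and bearing hydrogen-bond acceptors. Nothing at hand explains why these three aryl groups read alike.

The compounds shown leave open whether any group at this position can move the number beyond the scatter, since all three aryl groups carry only halogens or a nitro group. An aryl ring bearing an amine or a carboxylic acid, or a plain alkyl chain in place of the aryl ring, would test this.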